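The source may hold more compounds than are shown below. What is called first, only, known or untested is meant among the compounds shown, and "the series" means these compounds.

Values from a functional assay on the whole organism for antagonist activity, with Mus musculus as the target (a higher number here means that more compound is needed for the effect, a lower number that less compound is needed), follow for the two compounds measured so far:

Compound 1 `COC(=O)NCC#CCn1cncc1C`: 66 mg/kg
Compound 2 `COC(=O)N(C)CC#CCn1ccnc1`: > 100 mg/kg

Only compound 1 has a true number. Going by these compounds, compound 2 reached only a limit, > 100 mg/kg, and this is not a measured number, so its exact position is unknown.

Compound 3 `COC(=O)N(C)CC#CCn1cncc1C` has yet to be measured. It differs from compound 2 in one place: methyl in place of hydrogen on an aromatic carbon of the five-membered aromatic ring.

Among the measured compounds shown here, no two measured compounds differ in just one place, so no measured step shows what this change does. For the measured compounds named here, the only guide is compound 1, which also carries a methyl on the ring and gives 66 mg/kg in this assay as a real number. The estimated step of an at least 1.6-fold lower number from compound 2 to compound 3 (0.22 log units; that floor lies within the scatter) points toward less compound being needed, and its size is expected to be modest, though it starts from a limit and remains uncertain. Another result reported only as a limit is also possible. For compound 3 the expected value is 60 mg/kg, within an estimated range from 20 mg/kg to 150 mg/kg.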

Compound 3, dose for half-maximal effect: 3 mg/kg
Compound 3: the middle estimate sits 20-fold (1.30 log units) above what was measured; measured number outside the range, below it.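

In this assay, among the compounds shown here, the methyl on an aromatic carbon of the five-membered ring matters far more than the earlier compounds could show, with the step being an at least 33-fold lower number from compound 2 to compound 3 (1.52 log units; beyond the scatter). Compound 2 is held only by a limit of the assay, so this step gives a minimum and not an exact size: the limit of > 100 mg/kg in this assay, at which 1 of the 3 values shown sits. The methyl on the amide-type nitrogen matters as well, with the second step being a 22-fold lower number from compound 1 to compound 3 (1.34 log units; beyond the scatter), so compound 1, with only the ring methyl, and compound 2, with only the nitrogen methyl, each need clearly more compound than compound 3, which carries both.

The compounds shown leave open whether the two methyl groups act together or each on its own, a question that would need a compound with hydrogen in both places. They also leave open whether anything other than methyl would serve at either place, such as a chlorine atom on the ring carbon or a longer chain, like ethyl, on the amide-type nitrogen.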